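Working notes: compound 3 to compound 4

The source may hold more compounds than are shown below. What is called first, only, known or untested is meant among the compounds shown, and "the series" means these compounds.

Measured in a functional assay on MDA-MB-231 cells (Homo sapiens) for inhibition, read by MTT assay, with a stated time of 48 h; a higher number here means a weaker inhibitor of growth, a lower number a stronger inhibitor of growth
- compound 1 `S=C(Nc1ccc(Cl)cc1)Nc1ccc2ncnc(Nc3cccc(Br)c3)c2c1` gives 8200 nM
- compound 2 `NS(=O)(=O)c1ccc(NC(=S)Nc2ccc3ncnc(Nc4cccc(Br)c4)c3c2)cc1` gives > 30000 nM (a limit of the assay, not a number)
- compound 3 `Fc1ccc(NC(=S)Nc2ccc3ncnc(Nc4cccc(Br)c4)c3c2)cc1Cl` gives 300 nM

Compound 3 holds the lower of the two actual numbers (300 nM). Among the compounds with values here, the only numeric comparison is a 27-fold lower number from compound 1 to compound 3 (1.44 log units; beyond the scatter) and it is large. The other measured partner is a limit, so the step of an at least 100-fold lower number from compound 2 to compound 3 (2.00 log units; beyond the scatter) is large but is bounded rather than exact.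

Compound 4 `FC(F)(F)c1cccc(NC(=S)Nc2ccc3ncnc(Nc4cccc(Br)c4)c3c2)c1` keeps the shared core and carries 3-(trifluoromethyl)phenyl in place of 3-chloro-4-fluorophenyl on the amide-type nitrogen (3-(trifluoromethyl)phenyl in place of 3-chloro-4-fluorophenyl on an amide-type nitrogen). Both of those steps to compound 3 change this same place, and an at least 3.6-fold higher number from compound 1 to compound 2 (0.56 log units; beyond the scatter) shows further movement at the far end of the same group. Within the data shown here, no measured compound carries the entering group, so the size of the change is uncertain.

The change at this place has so far never been neutral, and compound 3 sits at the low end of the range. A move away from its group is therefore expected to raise the number in this assay. The expected change is a 4.0-fold higher number from compound 3 to compound 4 (0.60 log units; beyond the scatter), a moderate step to a higher number and smaller than the largest measured steps. The estimated value for compound 4 is 1200 nM (expected range 250 nM to 6000 nM)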

Compound 4, concentration for 50% growth inhibition: 1400 nM
Compound 4: the middle estimate sits 1.2-fold (0.07 log units) below what was measured, within the range that was stated.
By their numbers in this assay, from the lowest: compound 3; then compound 4; then compound 1. At a limit, above all of these: compound 2.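

In this assay, 3-(trifluoromethyl)phenyl gives a 4.7-fold higher number from compound 3 to compound 4 (0.67 log units; beyond the scatter), while the same group still gives a 5.9-fold lower number from compound 1 to compound 4 (0.77 log units; beyond the scatter), so compound 4 falls between the two earlier numeric results. With the third numeric value at this place, the groups on the amide-type nitrogen give a graded series across compound 3, compound 4 and compound 1, rather than a single low number set against a single high one. The step of an at least 21-fold lower number from compound 2 to compound 4 (1.33 log units; beyond the scatter) adds only a bound, as compound 2 is held at a limit of the assay and not at a number: the limit of > 30000 nM in this assay, at which 1 of the 4 values shown sits.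

As far as these compounds go, it remains open whether the number of compound 3 depends on both of its ring substituents, and a 3-chlorophenyl or a 4-fluorophenyl group on this nitrogen would separate the two. From the compounds shown here alone, it is also open whether the limit of compound 2 is particular to sulfamoyl or extends to other groups at that end of the ring, such as an amine or a carboxylic acid.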